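Adding bromo to a compound resting at the limit

The compounds below may be only part of what the source reports. "The series", "measured", "known", "first", "only" and "open" are said of these compounds alone.

Of the compounds shown here, three sharing one core have been read in a functional assay on DU-145 cells (Homo sapiens) for cytotoxicity, read by MTT assay, with a stated time of 48 h (a lower number here means a stronger inhibitor, a higher number a weaker inhibitor), so far. Compound 1 (`COc1ccc(/C=C/C(=O)/C=C/c2cc3ccccc3nc2Cl)cc1`) gives > 10000 nM as a limit and not a number. Compound 2 (`COc1ccc(/C=C/C(=O)/C=C/c2cc3ccccc3nc2Oc2ccccc2)cc1`) gives > 10000 nM as a limit too. Compound 3 (`COc1ccc(/C=C/C(=O)/C=C/c2cc3ccccc3nc2Oc2ccccc2)c(OC)c1`) gives > 10000 nM as another limit. Compound 2 therefore has no exact standing, and the whole set rests on the limit of > 10000 nM in this assay, at which 3 of the 3 values shown sit, without a single number.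

Compound 4 (`COc1ccc(/C=C/C(=O)/C=C/c2cc3ccccc3nc2Oc2ccc(Br)cc2)cc1`) carries one change from compound 2 (bromo in place of hydrogen on an aromatic carbon) in which phenoxy becomes 4-bromophenoxy. The measured guides are a step that the two limits leave unreadable from compound 1 to compound 2 and a step that the two limits leave unreadable from compound 2 to compound 3 and neither has a size to carry over, though the second also adds a group on an aromatic carbon. No sized shift or firm direction can therefore be expected in this assay and a reading at the same limit is the likeliest outcome. The expected change is a step that the limit leaves unreadable from compound 2 to compound 4 and it is only a rough estimate. For compound 4 the estimated value is 12000 nM with a range of 4000 nM to 30000 nM in this estimate.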

Compound 4, half-maximal inhibitory concentration: > 10000 nM
Compound 4: a limit, no number; the forecaster's own chance of this, stated with the estimate: 75%; the middle value lies beyond the limit too.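

In this assay compound 4 gives > 10000 nM, which is a limit and not a number. Neither its step from compound 1 nor its step from compound 2 can be read. The compounds shown leave open how strongly any of them acts, and whether any change to the shared core would give a measurable value: the limit of > 10000 nM in this assay, at which 4 of the 4 values shown sit.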